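Sulfonamide nitrogen substituents on a shared chromenone core

This account rests on a few compounds, and the source may have more. Where it says the series, first, only, none or still open, it means among the compounds named here.

Measured compounds, with their numbers in a functional assay on T47D cells (Homo sapiens) for cytotoxicity, read by sulforhodamine B assay, with a stated time of 48 h; on this read-out higher numbers stand for weaker inhibition and lower numbers for stronger inhibition:
compound 1 `NS(=O)(=O)c1ccc(N/C=C\C(=O)c2cc3ccccc3oc2=O)cc1` gives 109000 nM
compound 2 `N=C(N)NS(=O)(=O)c1ccc(N/C=C\C(=O)c2cc3ccccc3oc2=O)cc1` gives 87600 nM
compound 3 `Cc1nnc(NS(=O)(=O)c2ccc(N/C=C\C(=O)c3cc4ccccc4oc3=O)cc2)s1` gives 94000 nM

All three share the same core and differ only at the sulfonamide nitrogen. On the numbers, compound 3 stands second highest of the three, but its neighbours lie close: the step of a 1.1-fold higher number from compound 2 to compound 3 (0.03 log units; within the scatter) and the step of a 1.2-fold lower number from compound 1 to compound 3 (0.06 log units; within the scatter) are both within the scatter, as is a 1.2-fold lower number from compound 1 to compound 2 (0.09 log units; within the scatter). No ordering among the three is supported.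

Compound 4 `O=C(/C=C\Nc1ccc(S(=O)(=O)Nc2ncccn2)cc1)c1cc2ccccc2oc1=O` is the next step from compound 3: pyrimidin-2-yl in place of 5-methyl-1,3,4-thiadiazol-2-yl on a sulfonamide nitrogen. Within the data shown here, the steps that bear on this are those already made at the same place, a 1.2-fold lower number from compound 1 to compound 3 (0.06 log units; within the scatter) and a 1.1-fold higher number from compound 2 to compound 3 (0.03 log units; within the scatter), where a hydrogen, a three-atom group or the five-membered heteroaromatic ring made no difference beyond the scatter. Swapping one six-heavy-atom aromatic group for another at this position gives no reason to expect anything different. The expectation is therefore no step beyond the scatter, in either direction.

For compound 4 the estimated value in this assay is 95000 nM, with a range from 45000 nM to 190000 nM, which is expected to mean a step of a 1.0-fold higher number from compound 3 to compound 4 (0.00 log units; within the scatter).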

Compound 4, half-maximal inhibitory concentration: 75200 nM
Compound 4: the middle estimate sits 1.3-fold (0.10 log units) above what was measured; measured number inside the range.
By their numbers in this assay, from the lowest: compounds 4, 2, 3 and 1 (each within the scatter of the next).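

In this assay, exchanging the five-membered aromatic ring for a six-membered one on the sulfonamide nitrogen stays within the scatter, a 1.3-fold lower number from compound 3 to compound 4 (0.10 log units; within the scatter), so the ring type and the loss of the methyl group have no readable effect here. Measured against the simpler substituents, pyrimidin-2-yl gives the same outcome, both with the three-atom group, a 1.2-fold lower number from compound 2 to compound 4 (0.07 log units; within the scatter), and with hydrogen, a 1.4-fold lower number from compound 1 to compound 4 (0.16 log units; within the scatter). The position now spans hydrogen, an open-chain group and two different aromatic rings without a single step beyond the scatter, which extends the earlier flat picture to pyrimidin-2-yl, and no ordering among the four compounds is supported.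

No measurement at hand explains why the number stays so insensitive to this substituent. Still open, going by these compounds, is whether a carboxylic acid, a primary amine or a longer alkyl chain on the sulfonamide nitrogen would produce a step beyond the scatter, and whether a change to the shared core, rather than at this position, would move the number at all.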